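Swapping Chloro for Methyl in a Bicyclic Bisphosphate

This account rests on a few compounds, and the source may have more. Where it says the series, first, only, none or still open, it means among the compounds named here.

Compound 1 `CNc1nc(Cl)nc2c1ncn2[C@H]1C[C@H](OP(=O)(O)O)[C@]2(COP(=O)(O)O)C[C@H]12`: 52 nM
Compound 2 `Nc1nc(I)nc2c1ncn2C1CC(OP(=O)(O)O)[C@]2(COP(=O)(O)O)C[C@H]12`: 87 nM

Both compounds were tested in a functional assay for antagonist activity at P2Y purinoceptor 1 (Homo sapiens); a higher number here means a weaker inhibitor, a lower number a stronger inhibitor. Compound 1 has the lower of the two numbers, but compound 2 sits within the scatter of it, so the two cannot be ranked. Compound 3 `CNc1nc(C)nc2c1ncn2[C@H]1C[C@H](OP(=O)(O)O)[C@]2(COP(=O)(O)O)C[C@H]12` differs from compound 1 in one place: methyl in place of chloro on an aromatic carbon. Among the compounds with values here, no measured pair shows this exact change, so the expectation rests on the change alone. A modest step toward weaker inhibition, a 2.3-fold higher number from compound 1 to compound 3 (0.36 log units; beyond the scatter), is expected. For compound 3 the estimate is 120 nM, with a range from 40 nM to 400 nM.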

Compound 3, half-maximal inhibitory concentration: 49 nM
Compound 3: middle estimate off by 2.4-fold (0.39 log units), on the high side, and the stated range covers the measured number.
By their numbers in this assay, from the lowest: compounds 3, 1 and 2 (each within the scatter of the next).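

At this aromatic carbon between two ring nitrogen atoms, methyl in place of chloro gives no readable difference in this assay, with a 1.1-fold lower number from compound 1 to compound 3 (0.03 log units; within the scatter). On the core of compound 1, then, this position takes either group, and the step toward weaker inhibition seen for this swap in general does not appear here. Nothing available explains why the two groups read alike.

On these data alone, whether an amine or an ethyl group at this same carbon would also read alike stays open. So does whether the swap behaves the same way with the plain amino group of compound 2 in place of methylamino.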